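Swapping the methyl position on a benzimidazole dimer

The source may hold more compounds than are shown below. What is called first, only, known or untested is meant among the compounds shown, and "the series" means these compounds.

Two related compounds have been tested in a functional assay on RPMI 8402 cells (Homo sapiens) for cytotoxicity; on this read-out lower numbers stand for stronger inhibition and higher numbers for weaker inhibition. Compound 1 `Cc1ccc(-c2nc3cc(-c4nc5cc(C(N)=O)ccc5[nH]4)ccc3[nH]2)cc1` carries a 4-methylphenyl group at one end and a carboxamide at the other. Compound 2 `Cc1cccc(-c2nc3cc(-c4nc5cc(N6CCN(C)CC6)ccc5[nH]4)ccc3[nH]2)c1` instead carries a 3-methylphenyl group and a methylpiperazine. In this assay compound 1 reaches only > 25000 nM, which is a limit of the assay rather than a number. In this assay, within the data shown here, compound 2 gives 360 nM, the only true number so far, and it stands apart from compound 1, whose value sits at the limit of > 25000 nM in this assay, at which 1 of the 2 values shown sits. Among the measured compounds shown here, no single-change step connects these two, so the pair shows only that they differ in two places and in potency.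

Compound 3 `Cc1ccc(-c2nc3cc(-c4nc5cc(N6CCN(C)CC6)ccc5[nH]4)ccc3[nH]2)cc1` is not yet measured. It differs from compound 2 by 4-methylphenyl in place of 3-methylphenyl on an aromatic carbon. Moving a methyl group around a phenyl ring is a small change, and with no measured step of this kind to lean on, the expected step is a 1.4-fold higher number from compound 2 to compound 3 (0.14 log units; within the scatter), roughly none beyond the scatter. Compound 3 is therefore estimated at 500 nM, with a range from 150 nM to 3000 nM.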

Compound 3, half-maximal inhibitory concentration: 830 nM
The estimate for compound 3 lay 1.7-fold (0.22 log units) below the measured number; low and high end bracket the measured number.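

In this assay, the place of the methyl group on the phenyl ring turns out to matter, even though the two compounds have the same atoms: 4-methylphenyl in place of 3-methylphenyl gives a 2.3-fold higher number from compound 2 to compound 3 (0.36 log units; beyond the scatter), a modest step, but one beyond the usual scatter. Among these compounds, the new compound also gives the first single-change comparison at the other end of the molecule, where, with the 4-methylphenyl group held constant, 4-methylpiperazin-1-yl in place of carbamoyl gives an at least 30-fold lower number from compound 1 to compound 3 (1.47 log units; beyond the scatter), a large step. The value of compound 1 is a limit and not a number, so the true size of this step remains unknown and could be larger than printed: the limit of > 25000 nM in this assay, at which 1 of the 3 values shown sits.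

As far as these compounds go, it remains open how a plain phenyl group or a chlorophenyl group would compare with the two methylphenyl groups at this position. It is also unclear how much of the large step would survive with a piperazine lacking its methyl group, or with a simple primary amine or a carboxylic acid at that end of the molecule.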